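The source may hold more compounds than are shown below. What is called first, only, known or untested is meant among the compounds shown, and "the series" means these compounds.

Measured so far in a functional assay on HepG2 cells (Homo sapiens) for cytotoxicity, read by MTT assay, with a stated time of 72 h; a lower number here means a stronger inhibitor, a higher number a weaker inhibitor:
- compound 1 `O=C(Nc1ccc(Oc2ccnc3[nH]ccc23)cc1)c1nn(-c2ccc(Cl)cc2)ccc1=O`: 19500 nM
- compound 2 `COc1ccc(-n2ccc(=O)c(C(=O)Nc3ccc(Oc4ccnc5[nH]ccc45)cc3)n2)cc1`: 50800 nM
- compound 3 `O=C(Nc1ccc(Oc2ccnc3[nH]ccc23)cc1)c1nn(-c2ccccc2)ccc1=O`: 17800 nM

Compound 3 gives the lowest of the three numbers, but its gap to compound 1 is within the scatter a 1.1-fold lower number from compound 1 to compound 3 (0.04 log units; within the scatter), so no order between those two can be claimed; only compound 2 stands apart, as seen in a 2.9-fold lower number from compound 2 to compound 3 (0.46 log units; beyond the scatter).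

Compound 4 `O=C(Nc1ccc(Oc2ccnc3[nH]ccc23)cc1)c1nn(-c2ccc(Cl)c(F)c2)ccc1=O` differs from compound 3 by 4-chloro-3-fluorophenyl in place of phenyl on an aromatic nitrogen. The step that bears on this is a 1.1-fold lower number from compound 1 to compound 3 (0.04 log units; within the scatter): exchanging chloro for hydrogen on that ring changed nothing beyond the scatter. Among the compounds with values here, no measured compound carries a fluorine on this ring, so that part is unsupported. The step of a 1.0-fold lower number from compound 3 to compound 4 (0.02 log units; within the scatter) is therefore expected to be small, in either direction.

Compound 4 is estimated at 17000 nM in this assay, with a range from 8000 nM to 38000 nM.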

Compound 4, half-maximal inhibitory concentration: 5240 nM
The estimate for compound 4 lay 3.2-fold (0.51 log units) above the measured number; measured number below the stated range.
By their numbers in this assay, from the lowest: compound 4; then compounds 3 and 1 (each within the scatter of the next); then compound 2.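

Chloro alone on the ring held by the aromatic nitrogen left the number within the scatter, so the added fluoro is the first change on this ring to lower it, giving a 3.7-fold lower number from compound 1 to compound 4 (0.57 log units; beyond the scatter) and, for the whole 4-chloro-3-fluorophenyl group, a 3.4-fold lower number from compound 3 to compound 4 (0.53 log units; beyond the scatter). Exchanging the 4-methoxyphenyl group gives the widest step in this set, a 9.7-fold lower number from compound 2 to compound 4 (0.99 log units; beyond the scatter), so changes on this ring can move the number either way.

Nothing shown explains why the fluoro lowers the number. From the compounds shown here alone, whether fluoro without the chloro, or a nitrile or trifluoromethyl group on this ring, would do the same stays open.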